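The source may hold more compounds than are shown below. What is called first, only, known or untested is meant among the compounds shown, and "the series" means these compounds.

In a functional assay on MDA-MB-231 cells (Homo sapiens) for cytotoxicity, read by MTT assay, with a stated time of 72 h (on this read-out higher numbers stand for weaker inhibition and lower numbers for stronger inhibition), the measured compounds stand as follows:

Compound 1, `CN(C)CCCNc1nc(-c2ccc(NC(=O)Nc3ccccc3F)cc2)nc2ccsc12`, gives 660 nM.
Compound 2, `CN(C)CCCNc1nc(-c2ccc(NC(=O)Nc3ccccc3Cl)cc2)nc2ccsc12`, gives 590 nM.
Compound 3, `CN(C)CCNc1nc(-c2ccc(NC(=O)Nc3ccc(F)cc3)cc2)nc2c(Cl)c(Cl)sc12`, gives 1240 nM.

Compound 2 differs from compound 1 by one change, (chloro in place of fluoro on an aromatic carbon), and the measured step is a 1.1-fold lower number from compound 1 to compound 2 (0.05 log units; within the scatter). Compound 4, `CN(C)CCNc1nc(-c2ccc(NC(=O)Nc3ccc(Cl)cc3)cc2)nc2c(Cl)c(Cl)sc12`, is not yet measured; it differs from compound 3 by chloro in place of fluoro on an aromatic carbon. The difference between the core of compound 1 and the core of compound 3 is not broken down here. The two changes are the same kind of change, not the same: in the pair of compound 1 and compound 2 the exchanged atom sits ortho to a large group, whereas in the pair of compound 3 and compound 4 it sits para to a large group. Because the earlier pair gave a 1.1-fold lower number from compound 1 to compound 2 (0.05 log units; within the scatter), a step of similar size is expected here, and compound 4 is expected to show a 1.1-fold lower number from compound 3 to compound 4 (0.05 log units; within the scatter). Resting on compound 3 and its value 1240 nM, compound 4 is estimated at 1100 nM, likely between 550 nM and 2200 nM.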

Compound 4, half-maximal inhibitory concentration: 870 nM
The estimate for compound 4 lay 1.3-fold (0.10 log units) above the measured number, and the stated range covers the measured number.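

In this assay, replacing 4-fluorophenyl with 4-chlorophenyl gives a 1.4-fold lower number from compound 3 to compound 4 (0.15 log units; within the scatter). Set beside the earlier pair, the exchange of fluoro for chloro carries over from one core to the other with no step that can be told apart from the first: the same change on two cores in this assay, a 1.1-fold lower number (0.05 log units; within the scatter) from compound 1 to compound 2 and a 1.4-fold lower number (0.15 log units; within the scatter) from compound 3 to compound 4, 1.3-fold (0.11 log units) apart, within the scatter of two such steps. Among the compounds shown here, this shows only that the exchange stayed small on these two cores; it does not show that it would stay small on any other core, and the two pairs differ in the place of the exchanged atom as well as in the core, which four compounds cannot separate.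

The compounds shown leave open whether a step this small would also hold for a bromo or methoxy group in the same place on the ring. They also leave open how these cores would respond to a morpholine in place of the dimethylamino group, or to a longer chain ending in that amine.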